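Compound 2 to compound 4: a hydroxy replaces the chain

The compounds below may be only part of what the source reports. "The series", "measured", "known", "first", "only" and "open" are said of these compounds alone.

Three related compounds have been read so far in a functional assay on MCF7 cells (Homo sapiens) for inhibition, read by sulforhodamine B assay, with a stated time of 48 h; a lower number here means a stronger inhibitor, a higher number a weaker inhibitor. Compound 2 `COc1ccc(C(c2ccc(OC(C)CN(C)C)cc2)c2cccc3ccccc23)c(OC)c1OC` gives 13100 nM. Compound 3 `COc1ccc(/C(=C/c2ccc(F)cc2)c2cccc3ccccc23)c(OC)c1OC` gives 10500 nM, and the numbers of these two compounds lie within the scatter of each other. Compound 1 `COc1ccc(/C(=N/O)c2cccc3ccccc23)c(OC)c1OC` gives > 20000 nM, which is a limit of the assay and not a number.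

Compound 4 `COc1ccc(C(c2ccc(O)cc2)c2cccc3ccccc23)c(OC)c1OC` keeps the core of compound 2 and differs at one place: hydrogen in place of 1-((dimethylamino)methyl)ethyl on an oxygen on an aromatic ring. Hydrogen stands in place of 1-((dimethylamino)methyl)ethyl on an oxygen on an aromatic ring, so 1-((dimethylamino)methyl)ethoxy becomes hydroxy. Among the compounds with values here, no measured pair isolates this change, so the expectation rests on indirect comparison. Compound 3 carries no such chain and still gives 10500 nM, so no large loss is expected from removing it. Compound 1 also lacks the chain and stands at a limit, so a limit reading for compound 4 remains possible.

The expected 1.1-fold higher number from compound 2 to compound 4 (0.06 log units; within the scatter) stays within the scatter, with a slight lean toward a higher number. For compound 4 the estimated value is 15000 nM, with an expected range from 6000 nM to 32000 nM.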

Compound 4, half-maximal inhibitory concentration: 17500 nM
Compound 4: the middle estimate sits 1.2-fold (0.07 log units) below what was measured, and the stated range covers the measured number.
By their numbers in this assay, from the lowest: compounds 3, 2 and 4 (each within the scatter of the next). At a limit, above all of these: compound 1.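

In this assay, the series now has its first pair of compounds differing in one place, and the step reads a 1.3-fold higher number from compound 2 to compound 4 (0.13 log units; within the scatter). On this oxygen on an aromatic ring, the full 1-((dimethylamino)methyl)ethyl chain and a bare hydrogen therefore give numbers that cannot be told apart in this assay, so this one pair offers no sign that the chain, with its nitrogen, matters to the reading on the core of compound 2. Compound 1 stands at a limit of the assay, which marks the upper end of what the series can show here: the limit of > 20000 nM in this assay, at which 1 of the 4 values shown sits.

Going by these compounds, with only the two ends of the substitution compared, it remains open whether anything placed on this oxygen can move the number beyond the scatter, for example a small methyl ether, a longer chain ending in a morpholine, or a chain ending in a carboxylic acid. Also open, on these data alone, is whether a change elsewhere on the shared core, such as an amine or a fluorine on the ring that carries this oxygen, would give a number clearly lower than those of this pair.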